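The source may hold more compounds than are shown below. What is called first, only, known or untested is meant among the compounds shown, and "the series" means these compounds.

Of the compounds shown here, two sharing one core have been measured in a functional assay on A549 cells (Homo sapiens) for inhibition, read by CCK-8 assay, with a stated time of 48 h; a higher number here means a weaker inhibitor, a lower number a stronger inhibitor. Compound 1 `COc1cc(-c2ccnc3cc(-c4ccc(C)cc4)nn23)cc(OC)c1OC` gives 3 nM, while compound 2 `COc1cc(-c2ccnc3cc(-c4ccc(C)c(C)c4)nn23)cc(OC)c1OC` gives 272 nM, the higher of the two numbers and so the weaker inhibitor. The next compound, compound 3 `COc1cc(-c2ccnc3cc(-c4cccc(C#N)c4)nn23)cc(OC)c1OC`, keeps the core but carries 3-cyanophenyl in place of 3,4-dimethylphenyl on an aromatic carbon. Among the measured compounds shown here, only one measured step bears on this change, and it concerns the same aromatic ring: methyl in place of hydrogen gave a 91-fold higher number from compound 1 to compound 2 (1.96 log units; beyond the scatter), a large step. For the measured compounds named here, this single pair shows that a small edit to that ring can move the number a long way, but no measured compound carries a nitrile, so the pair cannot fix the size of this step. Going by the values given here, with both methyl groups of compound 2 gone, a slight lean toward a lower number is expected, though no step clearly beyond the scatter can be predicted. The estimated step is a 1.8-fold lower number from compound 2 to compound 3 (0.26 log units; within the scatter). For compound 3 the expected value is 150 nM, within an estimated range from 20 nM to 1000 nM.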

Compound 3, half-maximal inhibitory concentration: > 10000 nM
Compound 3: only a limit was reported; the forecaster's own chance of this, stated with the estimate: 5%; at least 66-fold (1.82 log units) between middle value and limit.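

Compound 3 is reported in this assay only as a limit, not as a number: the limit of > 10000 nM in this assay, at which 1 of the 3 values shown sits.

Even so, the step can be read as a minimum: replacing 3,4-dimethylphenyl with 3-cyanophenyl gives an at least 36-fold higher number from compound 2 to compound 3 (1.56 log units; beyond the scatter), and replacing 4-methylphenyl with 3-cyanophenyl gives an at least 3300-fold higher number from compound 1 to compound 3 (3.52 log units; beyond the scatter). The earlier pair showed only that adding one methyl to this aromatic ring raises the number, whereas these steps show that removing methyl groups does not by itself bring the number back down, since compound 3 has none and still has the highest reading of the three compounds.

Compound 3 differs from compound 1 both by losing the methyl and by gaining the nitrile, so these compounds cannot show how much of the large step belongs to each change. Also open, on these data alone, is how a plain phenyl ring, or a ring carrying an amine or a carboxylic acid, would read at this position, and how far above the limit the true number for compound 3 lies.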